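A few compounds are considered here, and "the series" means these few. Any claim that something is new, unique, unknown or untested is made for them only; others in the source may bear on it.

Compound 1 `CC(=O)N1CCC(NC(=O)c2ccncc2Nc2cc(-c3ccc4ccn(C)c4c3)c3nccnc3c2)CC1`: 213 ug/mL
Compound 2 `CC(=O)N1CC(NC(=O)c2ccncc2Nc2cc(-c3ccc4ccn(C)c4c3)c3nccnc3c2)C1`: 244 ug/mL

In a physicochemical assay for solubility, read by spectrophotometry, measured as kinetic solubility, at pH 8, tested at 500 uM (on this read-out lower numbers stand for lower solubility and higher numbers for higher solubility), compound 2 gives 244 ug/mL and cannot be told apart from compound 1, which gives 213 ug/mL. Compound 3 `CN1CCC(CNC(=O)c2ccncc2Nc2cc(-c3ccc4ccn(C)c4c3)c3nccnc3c2)C1` has not yet been measured. It departs from compound 2 on the amide-type nitrogen: (1-methylpyrrolidin-3-yl)methyl in place of 1-acetylazetidin-3-yl on an amide-type nitrogen. Among the measured compounds shown here, only one measured step bears on this change: a 1.1-fold higher number from compound 1 to compound 2 (0.06 log units; within the scatter). That step exchanges 1-acetylpiperidin-4-yl for 1-acetylazetidin-3-yl, so both groups carry the acetyl. For the measured compounds named here, no measured step shows what happens when a (1-methylpyrrolidin-3-yl)methyl group enters, so the guidance is limited. With that caution, no shift beyond the scatter is expected in this assay, and the expected step is a 1.2-fold lower number from compound 2 to compound 3 (0.08 log units; within the scatter). The estimated value for compound 3 is 205 ug/mL, with an expected range of 100 ug/mL to 270 ug/mL.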

Compound 3, solubility: 246 ug/mL
Estimate against measurement, compound 3: 1.2-fold (0.08 log units) below; measured number inside the range.
By their numbers in this assay, from the lowest: compounds 1, 2 and 3 (each within the scatter of the next).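

In this assay, a 1.0-fold higher number from compound 2 to compound 3 (0.00 log units; within the scatter) comes with (1-methylpyrrolidin-3-yl)methyl in place of 1-acetylazetidin-3-yl, and a 1.2-fold higher number from compound 1 to compound 3 (0.06 log units; within the scatter) comes with the same group in place of 1-acetylpiperidin-4-yl. Among the compounds shown here, the earlier step compared only two acetyl-bearing groups, whereas these two steps show that on this amide-type nitrogen a group without the acetyl and with a five-membered ring still gives a number that cannot be told apart from those of compound 1 and compound 2. Nothing available explains this result.

The ring, the methyl and the chain to the amide-type nitrogen differ together. The (1-acetylpyrrolidin-3-yl)methyl group would be needed to separate them. The compounds also leave open whether a carboxylic acid or an open-chain amine on this nitrogen would stay within the scatter.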